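A few compounds are considered here, and "the series" means these few. Any claim that something is new, unique, unknown or untested is made for them only; others in the source may bear on it.

In a functional assay on the whole organism with Mus musculus as the target (on this read-out lower numbers stand for an effect already at smaller amounts and higher numbers for an effect only at larger amounts of compound), compound 3 (`Cn1nc(-c2ccccc2)n(C)c1=S`) gives 0.13 mg/kg. Compound 2 (`Cn1nc(-c2ccccc2F)n(C)c1=S`) gives 0.23 mg/kg, so compound 3 stands within the scatter of it. Compound 1 (`Cn1nc(-c2c(Cl)cccc2Cl)n(C)c1=S`) is recorded only as a limit, > 100 mg/kg, and not as a number.

The change to compound 4 (`Cn1nc(-c2ccccc2Cl)n(C)c1=S`) is chloro in place of hydrogen on an aromatic carbon, which puts chloro in place of hydrogen on an aromatic carbon. The closest measured step is the reverse kind of exchange at an aromatic carbon, with hydrogen in place of fluoro, and it comes to a 1.8-fold lower number from compound 2 to compound 3 (0.25 log units; within the scatter). For the measured compounds named here, that is the only measured step between two numbers, and it stays within the scatter. It therefore gives no support for a large shift in this assay when a single halogen is exchanged for hydrogen.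

Compound 1 also carries chloro on its aromatic ring and has no number, so a modest rise is expected rather than none, and the range is left wider on the upper side. The expected change is a 2.7-fold higher number from compound 3 to compound 4 (0.43 log units; beyond the scatter), an estimate of a small step towards a higher number.

For compound 4 the estimated value is 0.35 mg/kg, with an expected range from 0.1 mg/kg to 3 mg/kg.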

Compound 4, dose for half-maximal effect: 0.58 mg/kg
For compound 4 the middle estimate is 1.7-fold (0.22 log units) below the measured one; the measured number falls inside the stated range.
By their numbers in this assay, from the lowest: compounds 3 and 2 (each within the scatter of the next); then compound 4. At a limit, above all of these: compound 1.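

In this assay, for the compounds shown here, chloro on this aromatic carbon, ortho to a group of 8 heavy atoms, moves the read-out beyond the scatter, with a 4.5-fold higher number from compound 3 to compound 4 (0.65 log units; beyond the scatter), whereas the only earlier step between two numbers at this carbon stayed within it, with a 1.8-fold lower number from compound 2 to compound 3 (0.25 log units; within the scatter). The identity of the halogen therefore counts at this position, since chloro in place of fluoro gives a 2.5-fold higher number from compound 2 to compound 4 (0.40 log units; beyond the scatter). Compound 1 is held only as a limit and not as a number, and with an at least 170-fold lower number from compound 1 to compound 4 (2.23 log units; beyond the scatter), a single chloro costs far less on this ring than the pair of chloro groups in compound 1: the limit of > 100 mg/kg in this assay, at which 1 of the 4 values shown sits.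

A bromo or a methoxy group on this carbon would show whether the rise from hydrogen to chloro continues with other groups, and a single chloro elsewhere on the aromatic ring would show whether the change depends on this position at all. How large the step to compound 1 really is stays open, and the cause of the rise with chloro cannot be read from these compounds.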